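The source may report more compounds than this note shows. Statements on the series, on what has been measured and on what is new or still open speak of the compounds shown alone.

Compound 1 `O=C(CCCCC(=O)N1CCNCC1)N1CCNCC1` gives 34.5% in a functional assay on the whole organism with Mus musculus as the target, in the writhing test, at a dose of 5 mg/kg by the subcutaneous route; on this read-out lower numbers stand for less inhibition and higher numbers for more inhibition at the one dose given (going by the name of the read-out). Compound 2 `C(CN1CC[N+]2(CCCC2)CC1)CN1CC[N+]2(CCCC2)CC1` gives 45.5% in this assay, and compound 3 `CCOC(CN1CC[N+]2(CCCC2)CC1)CN1CC[N+]2(CCCC2)CC1` gives 34%. Among the compounds with values here, the one single-point step among the measured compounds is a number 11.5 percentage points lower from compound 2 to compound 3 (beyond the scatter). On these numbers compound 3 holds the lowest of the three, although its gap to compound 1 is within the scatter, while its gap to compound 2 is beyond it.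

Compound 4 `CCCCCCOC(CN1CC[N+]2(CCCC2)CC1)CN1CC[N+]2(CCCC2)CC1` differs from compound 3 by butyl in place of hydrogen on a saturated chain carbon, two bonds along the chain from an oxygen on a saturated carbon. Within the data shown here, no measured step bears directly on lengthening the chain beyond the oxygen; the only step that touches this part of the structure is the placing of the ethoxy group itself, a number 11.5 percentage points lower from compound 2 to compound 3 (beyond the scatter), which was modest in size. With nothing to show that a longer chain moves the number further, compound 4 is expected to give about 30%, in a range from 15% to 45%, a change of a number 4 percentage points lower from compound 3 to compound 4 (within the scatter) that is estimated to stay within the scatter.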

Compound 4, a percentage reported as inhibition, in the whole organism at one dose (the size of the read-out at that dose, not a potency): 61%
Compound 4: middle estimate off by 31 percentage points, on the low side; the measured number lies above the stated range.
By their numbers in this assay, from the lowest: compounds 3 and 1 (each within the scatter of the next); then compound 2; then compound 4.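

The carbon bearing the oxygen chain proves sensitive to the length of that chain: in this assay, going from ethoxy to hexyloxy gives a number 27 percentage points higher from compound 3 to compound 4 (beyond the scatter) and reverses the direction of the earlier step, a number 11.5 percentage points lower from compound 2 to compound 3 (beyond the scatter). A substituent here therefore need not lower the number, since hexyloxy in place of hydrogen gives a number 15.5 percentage points higher from compound 2 to compound 4 (beyond the scatter) and places compound 4 above the unsubstituted compound 2. Nothing available explains this reversal.

With only ethoxy and hexyloxy at this position, the compounds shown leave open whether the number climbs steadily with chain length or turns at some intermediate length, as a propoxy or butoxy group could show. They also leave open whether a longer chain such as octyloxy, or a different group such as benzyloxy or a free hydroxyl, would carry the number further.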